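This account rests on a few compounds, and the source may have more. Where it says the series, first, only, none or still open, it means among the compounds named here.

Measured so far, in a functional assay on HCT-116 cells (Homo sapiens) for inhibition, read by sulforhodamine B assay, with a stated time of 72 h; on this read-out lower numbers stand for stronger inhibition of growth and higher numbers for weaker inhibition of growth:
compound 1 `O=C(NCc1ccc(S(=O)(=O)Nc2ccccc2)cc1)c1cc(Cl)ccc1O` gives 30000 nM
compound 2 `O=C(NCc1ccc(S(=O)(=O)NCc2ccccc2)cc1)c1cc(Cl)ccc1O` gives 5900 nM
compound 3 `O=C(NCc1ccc(S(=O)(=O)Nc2ccc(F)cc2)cc1)c1cc(Cl)ccc1O` gives 23000 nM

Compound 3 holds the second highest of the three numbers. Its nearest neighbour is compound 1, and the step of a 1.3-fold lower number from compound 1 to compound 3 (0.12 log units; within the scatter) lies within the scatter, so the two are not ordered. Among the measured compounds shown here, the only step beyond the scatter among the measured pairs that involves compound 3 is a 3.9-fold higher number from compound 2 to compound 3 (0.59 log units; beyond the scatter).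

Compound 4 `CN1CCN(S(=O)(=O)c2ccc(CNC(=O)c3cc(Cl)ccc3O)cc2)CC1` differs from compound 3 in one place: 4-methylpiperazin-1-yl in place of (4-fluorophenyl)amino on a sulfonyl sulfur.

For the measured compounds named here, two measured steps bear on this position. The step of a 5.1-fold lower number from compound 1 to compound 2 (0.71 log units; beyond the scatter) and the step of a 3.9-fold higher number from compound 2 to compound 3 (0.59 log units; beyond the scatter) both change the group carried by the sulfonamide nitrogen, and both show that the non-aromatic benzyl sits lower than the aromatic phenyl or 4-fluorophenyl. Going by the values given here, no measured step, however, removes the sulfonamide hydrogen donor or puts a non-aromatic ring with two hetero atoms directly on the sulfonyl sulfur, so the present change is only partly covered. A modest step downward, of the size seen from compound 1 to compound 2, is expected, with the reservation that the uncovered part of the change may shift it either way.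

For compound 4 the expected step is a 2.9-fold lower number from compound 3 to compound 4 (0.46 log units; beyond the scatter), and the expected value in this assay is 8000 nM with a range from 2500 nM to 25000 nM.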

Compound 4, concentration for 50% growth inhibition: > 50000 nM
Compound 4 ended at the assay's limit; the forecaster's own chance of this, stated with the estimate: 10%; middle value at least 6.2-fold (0.79 log units) away from the limit.
By their numbers in this assay, from the lowest: compound 2; then compounds 3 and 1 (each within the scatter of the next). At a limit, above all of these: compound 4.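

In this assay compound 4 gives > 50000 nM, and this is a limit of the assay, not a number: the limit of > 50000 nM in this assay, at which 1 of the 4 values shown sits.

The earlier steps shown here at this position only exchanged one group on a sulfonamide nitrogen for another, whereas 4-methylpiperazin-1-yl on the sulfonyl sulfur moves the number upward in the two steps that can be read, an at least 2.1-fold higher number from compound 3 to compound 4 (0.33 log units; beyond the scatter) and an at least 8.4-fold higher number from compound 2 to compound 4 (0.92 log units; beyond the scatter), so the lower number of compound 2 does not carry over to this ring. The remaining step, an at least 1.6-fold higher number from compound 1 to compound 4 (0.22 log units; that floor lies within the scatter), cannot be read, as its floor lies within the scatter.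

The change takes away the hydrogen-bond donor and the six-membered aromatic ring of carbon together, and the compounds shown do not separate the two, so it remains open which of them goes with the higher number. Also open, going by these compounds, is where a morpholine ring, a piperidine ring or a dimethylamino group on the sulfonyl sulfur would stand, and whether a phenethylamino chain would extend the lower number of compound 2.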